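Dropping the Fluorine from the Sulfonyl Aryl Ring

The source may report more compounds than this note shows. Statements on the series, on what has been measured and on what is new or still open speak of the compounds shown alone.

Measured so far:
Compound 1 `CC1CCN(c2c(S(=O)(=O)c3ccc(F)c(Cl)c3)cnc3cc(Cl)ccc23)CC1` gives 94% in an assay on isolated protein for displacement of a labelled ligand from metabotropic glutamate receptor 5 (Homo sapiens), with a stated time of 60 min, tested at 1 uM; a higher number here means more inhibition at the concentration tested (going by the name of the read-out), a lower number less inhibition.
Compound 2 `CC1CCN(c2c(S(=O)(=O)c3cccc(Cl)c3)cnc3cc(Cl)ccc23)CC1` gives 92%.
Compound 3 `CC1CCN(c2c(S(=O)(=O)c3ccc(F)cc3)cnc3ccc(Cl)cc23)CC1` gives 89%.

From compound 1 to compound 2 the change is hydrogen in place of fluoro on an aromatic carbon, and the step was a number 2 percentage points lower from compound 1 to compound 2 (within the scatter). Compound 4 `CC1CCN(c2c(S(=O)(=O)c3ccccc3)cnc3ccc(Cl)cc23)CC1` has not been measured yet; it arises from compound 3 by hydrogen in place of fluoro on an aromatic carbon. This is the same kind of change, not the same: in the first pair the place is also ortho to a chloro group, which is absent in the second pair. The difference between the core of compound 1 and the core of compound 3 is not broken down here. Because the earlier step was a number 2 percentage points lower from compound 1 to compound 2 (within the scatter), only a small step is expected in this assay: a number 2 percentage points lower from compound 3 to compound 4 (within the scatter). Compound 4 is therefore estimated at 87%, between 75% and 95%.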

Compound 4, a percentage reported as inhibition, at one concentration (the size of the read-out at that concentration, not a potency): 59%
Compound 4: the middle estimate sits 28 percentage points above what was measured; measured number below the stated range.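

Replacing 4-fluorophenyl with phenyl gives a number 30 percentage points lower from compound 3 to compound 4 (beyond the scatter) in this assay. The size of this change therefore does not carry over from one core to the other in this small set: the same change on two cores in this assay, a number 2 percentage points lower (within the scatter) from compound 1 to compound 2 and a number 30 percentage points lower (beyond the scatter) from compound 3 to compound 4, 28 percentage points apart, beyond the scatter of two such steps What this does not show is which difference between the two pairs matters, the chloro group that the first pair also carries on the sulfonyl aryl ring or the rest of the core, and two pairs give no rule for other cores.

The compounds shown leave open whether a different group at that spot on compound 4, such as methoxy, nitrile or an amine, would behave like the fluoro group of compound 3.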